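Swapping a 2-chlorophenyl for a 2-phenylethenyl arm

The compounds below may be only part of what the source reports. "The series", "measured", "known", "first", "only" and "open" are said of these compounds alone.

Compound 1 `Cc1cc(O)c(C2=NN(c3ccc(S(N)(=O)=O)cc3)C(c3ccccc3O)C2)cc1Cl` gives 5100 nM in a functional assay on HT-29 cells (Homo sapiens) for antiproliferative activity, with a stated time of 48 h; on this read-out lower numbers stand for stronger inhibition of growth and higher numbers for weaker inhibition of growth.
Compound 2 `Cc1cc(O)c(C2=NN(c3ccc(S(N)(=O)=O)cc3)C(c3ccccc3Cl)C2)cc1Cl` gives 3630 nM in this assay.

Compound 2 shows the lowest of the two numbers, but its step from compound 1 is small: a 1.4-fold lower number from compound 1 to compound 2 (0.15 log units; within the scatter). Compound 3 `Cc1cc(O)c(C2=NN(c3ccc(S(N)(=O)=O)cc3)C(/C=C/c3ccccc3)C2)cc1Cl` differs from compound 2 in one place: 2-phenylethenyl in place of 2-chlorophenyl on a saturated ring carbon. Among the compounds with values here, no measured step involves this kind of exchange, so only the closeness of compound 1 and compound 2 offers any guide. For compound 3 the expected step is a 1.0-fold lower number from compound 2 to compound 3 (0.00 log units; within the scatter), meaning no change beyond the scatter, with a wide band of uncertainty. Compound 3 is therefore estimated at 3600 nM in this assay, between 1000 nM and 13000 nM.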

Compound 3, concentration for total growth inhibition: 14700 nM
Compound 3: middle estimate off by 4.1-fold (0.61 log units), on the low side; the measured number lies above the stated range.
By their numbers in this assay, from the lowest: compounds 2 and 1 (each within the scatter of the next); then compound 3.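

This saturated ring carbon is not indifferent to what it carries: in this assay there is a 4.0-fold higher number from compound 2 to compound 3 (0.61 log units; beyond the scatter) and also a 2.9-fold higher number from compound 1 to compound 3 (0.46 log units; beyond the scatter) for the same arm. So 2-chlorophenyl and 2-hydroxyphenyl stay within the scatter of each other, while 2-phenylethenyl, with its double bond outside the aromatic ring, weakens growth inhibition modestly. Nothing here explains this loss. From the compounds shown here alone, it stays open whether the double bond itself matters, which a saturated 2-phenylethyl arm could show. How an aminomethyl group would fare on this carbon is also unknown.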